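The source may report more compounds than this note shows. Statements on the series, on what has been measured and on what is new or still open speak of the compounds shown alone.

Measured compounds:
- compound 1 `O=C1Nc2ccc(Cl)cc2/C1=N/NC(=S)Nc1ccc(Cl)cc1`: in a functional assay on CCRF-CEM cells (Homo sapiens), with a stated time of 72 h (on this read-out higher numbers stand for weaker inhibition and lower numbers for stronger inhibition), compound 1 gives 61000 nM
- compound 2 `Cc1ccc(NC(=S)N/N=C2\C(=O)Nc3cc(Cl)c(F)cc32)cc1`: in this assay compound 2 gives 132000 nM

Of these two numbers, compound 1 stands at the lower one, and compound 2 lies higher by a gap beyond the usual scatter. For the measured compounds named here, the pair differs in more than one place, so the two values show only that compound 2 is the weaker inhibitor here.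

Compound 3 `O=C1Nc2ccc(F)cc2/C1=N/NC(=S)Nc1ccc(Cl)cc1` has not been measured. It differs from compound 1 in one place: fluoro in place of chloro on an aromatic carbon. Going by the values given here, no measured pair shows this exchange on its own, so nothing here sets its size. The expectation is a step from compound 1 to compound 3 of no size beyond the scatter, if anything a slightly higher number, as expressed in a 1.3-fold higher number from compound 1 to compound 3 (0.12 log units; within the scatter). Compound 3 is therefore estimated at 80000 nM, with a range from 30000 nM to 250000 nM.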

Compound 3, half-maximal inhibitory concentration: 25000 nM
The estimate for compound 3 lay 3.2-fold (0.51 log units) above the measured number; the whole stated range lies above it.
By their numbers in this assay, from the lowest: compound 3; then compound 1; then compound 2.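

In this assay, for the compounds shown here, fluoro in place of chloro on an aromatic carbon of the fused system of two rings gives a 2.4-fold lower number from compound 1 to compound 3 (0.39 log units; beyond the scatter), the first exchange here that can be read on its own. The position is therefore not indifferent to which halogen it carries, even though one heavy atom replaces one heavy atom and the counted hydrogen-bond donors and acceptors stay the same. The step is modest, and no measurement at hand accounts for it.

The compounds shown leave open how hydrogen, bromo or methoxy on this same carbon would compare with fluoro and chloro. They also leave open whether the exchange gives a step of similar size when methyl replaces the chloro on the other aromatic ring.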